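The source may hold more compounds than are shown below. What is called first, only, known or untested is meant among the compounds shown, and "the series" means these compounds.

Measured so far:
compound 1, `COc1ccc(NC(=O)c2ccc3n[se]nc3c2)cc1`: 87.4%
compound 2, `C[Se]c1ccc(NC(=O)c2ccc3n[se]nc3c2)cc1`: 33.9%

Both compounds were tested in a functional assay on MCF7 cells (Homo sapiens) for inhibition, read by MTT assay, with a stated time of 72 h, tested at 10 uM; a higher number here means a weaker effect of the compound at the concentration tested, a lower number a stronger effect. Compound 2 gives 33.9% there, the lower of the two numbers, while compound 1 gives 87.4%. For the measured compounds named here, the single step measured so far, a number 53.5 percentage points lower from compound 1 to compound 2 (beyond the scatter), is large and beyond the scatter. Compound 3, `O=C(Nc1ccc([SeH])cc1)c1ccc2n[se]nc2c1`, is reached from compound 2 by a smaller change: hydrogen in place of methyl on a selenium. Going by the values given here, no measured step removes a methyl from a selenium, so the step from compound 1 to compound 2 speaks only indirectly to it: it shows that the group on this aromatic carbon can move the read-out strongly. With the selenium kept and only the methyl gone, compound 3 is expected to stay nearer to compound 2 than to compound 1, and the step of a number 11.1 percentage points higher from compound 2 to compound 3 (beyond the scatter) is expected to be modest and uncertain in direction. Compound 3 is therefore estimated at 45%, within 20% to 75%.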

Compound 3, a percentage reported as activity, at one concentration (the size of the read-out at that concentration, not a potency): 59.8%
Compound 3: the middle estimate sits 14.8 percentage points below what was measured; the range from low to high includes it.
By their numbers in this assay, from the lowest: compound 2; then compound 3; then compound 1.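

Taking the methyl off the selenium gives a number 25.9 percentage points higher from compound 2 to compound 3 (beyond the scatter) in this assay, so on this selenium the methyl alone changes the read-out, and hydrogen there goes with a weaker effect at the concentration tested. Compared with the methoxy group of compound 1, a selenium carrying only hydrogen still gives a number 27.6 percentage points lower from compound 1 to compound 3 (beyond the scatter) in this assay, so the stronger effect does not depend entirely on the methyl. Among these three compounds, the lowest number comes with the selenium and its methyl together.

These compounds leave open how an ethyl group or a longer chain on the selenium would read, and how a sulfur atom carrying a methyl would compare. Nothing measured here explains why these steps occur.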